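From 3-Chlorophenyl to 2-Methylphenyl on the Shared Core

The source may report more compounds than this note shows. Statements on the series, on what has been measured and on what is new or still open speak of the compounds shown alone.

Two compounds built on a shared core have numbers in a functional assay on MGC-803 cells (Homo sapiens) for cytotoxicity, read by MTT assay, with a stated time of 72 h; a lower number here means a stronger inhibitor, a higher number a weaker inhibitor. Compound 1, `O=C(NC(=S)NNc1ncnc2ccccc12)c1cccc(Cl)c1`, gives 4540 nM in this assay. Compound 2, `COc1cc2ncnc(NNC(=S)NC(=O)c3ccccc3F)c2cc1OC`, gives 2390 nM in this assay. Compound 1 has the highest of the two numbers, and its nearest neighbour is compound 2, whose number lies within the scatter of repeated measurements of this kind, so no order between the two can be claimed. Going by the values given here, compound 2 differs from compound 1 in more than one place, and no step between measured compounds that differ in a single place is known.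

The step followed here runs from compound 1 to compound 3, `Cc1ccccc1C(=O)NC(=S)NNc1ncnc2ccccc12`, which has not yet been measured in this assay. The change is 2-methylphenyl in place of 3-chlorophenyl on a carbonyl carbon. Among the compounds with values here, no measured pair shows what such a change does, so the expectation rests on compound 1 alone, whose value 4540 nM is the starting point. Compound 3 is expected to give about 4000 nM in this assay, between 1500 nM and 12000 nM. That estimate means a step of a 1.1-fold lower number from compound 1 to compound 3 (0.05 log units; within the scatter), expected to stay within the usual scatter, in no sure direction.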

Compound 3, half-maximal inhibitory concentration: 4240 nM
For compound 3 the middle estimate is 1.1-fold (0.03 log units) below the measured one; the range from low to high includes it.
By their numbers in this assay, from the lowest: compounds 2, 3 and 1 (each within the scatter of the next).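

In this assay, putting 2-methylphenyl in place of 3-chlorophenyl on the carbonyl carbon gives a 1.1-fold lower number from compound 1 to compound 3 (0.03 log units; within the scatter), the first step shown that differs in a single place, and it lets this position be read directly for the first time on the shared core. The two groups have the same count of heavy atoms and the same aromatic ring of carbon only, and across this exchange of a chlorine-bearing ring for a methyl-bearing one the assay does not tell compound 1 and compound 3 apart. Going by these compounds alone, nothing available explains this result, and the single step cannot separate the identity of the ring substituent from its placement on the ring.

The compounds shown leave open whether any change at this carbonyl carbon can move the number beyond the scatter, since only two substituted phenyl groups are compared there on this core. A phenyl ring carrying a carboxylic acid or an amine, or a longer chain such as butyl in place of the ring, could show whether this position stays as unresponsive as this one step suggests.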